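A few compounds are considered here, and "the series" means these few. Any claim that something is new, unique, unknown or untested is made for them only; others in the source may bear on it.

Compound 1, `COc1ccc2ncc(S(=O)(=O)c3cccc(C#N)c3)c(N3CCC(C)CC3)c2c1` — in an assay on isolated protein for displacement of a labelled ligand from metabotropic glutamate receptor 5 (Homo sapiens), with a stated time of 60 min, tested at 1 uM (a lower number here means less inhibition, a higher number more inhibition at the concentration tested (going by the name of the read-out)), compound 1 gives 90%.
Compound 2, `COc1ccc2ncc(S(=O)(=O)c3cccc(Cl)c3)c(N3CCC(C)CC3)c2c1` — in this assay compound 2 gives -3%.
Compound 3, `CC1CCN(c2c(S(=O)(=O)c3cccc(Cl)c3)cnc3ccc(F)cc23)CC1` — in this assay compound 3 gives 92%.

Among these three, compound 2 stands at the bottom of the numbers in this assay: its nearest neighbour is compound 1, and the move a number 93 percentage points lower from compound 1 to compound 2 (beyond the scatter) is marked as beyond the scatter, as is the move a number 95 percentage points higher from compound 2 to compound 3 (beyond the scatter) to compound 3.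

Compound 4, `COc1ccc2ncc(S(=O)(=O)c3ccc(OC)c(OC)c3)c(N3CCC(C)CC3)c2c1`, has not yet been measured in this assay. It differs from compound 2 in one place: 3,4-dimethoxyphenyl in place of 3-chlorophenyl on a sulfonyl sulfur.

Among the compounds with values here, of the two measured steps, the one from compound 1 to compound 2 bears most closely on this change, since it too alters the aromatic group on the sulfonyl sulfur, and it was large: a number 93 percentage points lower from compound 1 to compound 2 (beyond the scatter). The step from compound 2 to compound 3 touches the core instead, and was also large: a number 95 percentage points higher from compound 2 to compound 3 (beyond the scatter). Both show that compound 2 sits at a point from which single changes have moved the read-out in this assay by a great deal, yet neither tells directly what two methoxy groups in place of one chloro group will do. The account therefore expects a step in this assay from compound 2 to compound 4 of uncertain size, more likely upward than downward, estimated as a number 43 percentage points higher from compound 2 to compound 4 (beyond the scatter). For compound 4 the expected value in this assay is estimated at 40%, within a range of -5% to 90%.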

Compound 4, a percentage reported as inhibition, at one concentration (the size of the read-out at that concentration, not a potency): -3%
Beside the measured number, compound 4's estimate is 43 percentage points above it, within the range that was stated.
By their numbers in this assay, from the lowest: compounds 2 and 4 (each within the scatter of the next); then compounds 1 and 3 (each within the scatter of the next).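

Changing 3-chlorophenyl to 3,4-dimethoxyphenyl on the sulfonyl sulfur gives no change at the digits printed from compound 2 to compound 4 (within the scatter) in this assay on the shared core, so the low number of compound 2 is not peculiar to the chloro group, and the extra heavy atoms and hydrogen-bond acceptors of the entering group brought no movement. The 3-cyanophenyl group now stands apart at this position, as changing it to 3,4-dimethoxyphenyl gives a number 93 percentage points lower from compound 1 to compound 4 (beyond the scatter) in this assay and this matches the large drop already seen with 3-chlorophenyl. Nothing available here explains why the nitrile-bearing group differs from the other two.

On these data alone, it remains open whether the high number of compound 1 depends on the nitrile itself or would survive with a carboxylic acid or a primary amide in its place on the phenyl ring. As far as these compounds go, it is also open whether fluoro in place of methoxy on the core, which marks compound 3, would lift the number of a compound carrying 3,4-dimethoxyphenyl as it did for the one carrying 3-chlorophenyl.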